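The source may hold more compounds than are shown below. What is called first, only, known or untested is meant among the compounds shown, and "the series" means these compounds.

Compound 3 `Cc1c(-c2csc(/N=C3\S/C(=C\c4ccccc4)C(=O)N3c3ccccc3)n2)c(=O)n(-c2ccccc2)n1C` stands at a limit: in a functional assay on MCF7 cells (Homo sapiens) for cytotoxicity, read by sulforhodamine B assay, with a stated time of 72 h (a higher number here means a weaker inhibitor, a lower number a stronger inhibitor), compound 3 gives > 100000 nM, which is a limit of the assay and not a number. Compound 1 `CC(=O)c1nn(-c2ccc(C)cc2)/c(=N/c2nc(-c3c(C)n(C)n(-c4ccccc4)c3=O)cs2)s1` gives 56800 nM in this assay. Compound 2 `CCOC(=O)c1nn(-c2ccc(Cl)cc2)/c(=N/c2nc(-c3c(C)n(C)n(-c4ccccc4)c3=O)cs2)s1` gives > 100000 nM in this assay, again a limit. Two of the three values shown thus sit at the limit of > 100000 nM in this assay, at which 2 of the 3 values shown sit. Compound 4 `COc1ccc(/C=C2\S/C(=N\c3nc(-c4c(C)n(C)n(-c5ccccc5)c4=O)cs3)N(c3ccccc3)C2=O)cc1` differs from compound 3 in one place: methoxy in place of hydrogen on an aromatic carbon. Among the measured compounds shown here, no step between measured compounds is available, so no size of effect can be read from the data. The expected step in this assay is a number no higher from compound 3 to compound 4 (the limit leaves the size open), nothing beyond the scatter, with a strong chance that only a limit is reported again. Compound 4 is therefore estimated at 100000 nM, within 40000 nM to 250000 nM.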

Compound 4, half-maximal inhibitory concentration: 26100 nM
Estimate against measurement, compound 4: 3.8-fold (0.58 log units) above; measured number outside the range, below it.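

In this assay, among the compounds shown here, the change from phenyl to 4-methoxyphenyl gives the only readable step at this position (an at least 3.8-fold lower number from compound 3 to compound 4 (0.58 log units; beyond the scatter)), and it lies beyond the scatter. This position is therefore not indifferent to substitution: methoxy, para to a large group, brings a measurable value where hydrogen left only a limit. The full size of the step stays open, since the value of compound 3 is a limit of the assay: the limit of > 100000 nM in this assay, at which 2 of the 4 values shown sit.

The compounds shown leave open whether a hydroxyl or an amine at this place would lower the number further. They also leave open whether methoxy elsewhere on that ring would act alike.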